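The source may report more compounds than this note shows. Statements on the series, on what has been measured and on what is new or still open speak of the compounds shown alone.

Working notes on the series. In an assay on cells for displacement of a labelled ligand from Neuronal acetylcholine receptor; alpha3/beta4 (Homo sapiens) (on this read-out higher numbers stand for weaker inhibition and lower numbers for stronger inhibition), compound 1 `COc1cc(NC(=O)c2cncc(N3CC4CC(C3)N4)c2)cc(OC)c1` gives 2000 nM, compound 2 `O=C(c1cncc(N2CC3CC(C2)N3)c1)N1CCCc2ccccc21` gives 62 nM and compound 3 `O=C(Nc1ccccc1F)c1cncc(N2CC3CC(C2)N3)c1` gives 102 nM. Compound 3 thus stands well apart from compound 1 and close to compound 2, the gap to compound 2 lying within the scatter and the gap to compound 1 beyond it. Compound 4 `CCc1cccc(NC(=O)c2cncc(N3CC4CC(C3)N4)c2)c1` differs from compound 3 in one place: 3-ethylphenyl in place of 2-fluorophenyl on an amide-type nitrogen. For the measured compounds named here, no measured pair shows this change. A small step toward weaker inhibition is expected in this assay, of a size that may not exceed the scatter, as a 2.0-fold higher number from compound 3 to compound 4 (0.29 log units; within the scatter). Compound 4 is therefore estimated at 200 nM in this assay, within a range from 60 nM to 700 nM.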

Compound 4, inhibition constant: 306 nM
Estimate against measurement, compound 4: 1.5-fold (0.18 log units) below; the measured number falls inside the stated range.
By their numbers in this assay, from the lowest: compounds 2 and 3 (each within the scatter of the next); then compound 4; then compound 1.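

In this assay, the group on the amide-type nitrogen now has its first readable step: 3-ethylphenyl in place of 2-fluorophenyl gives a 3.0-fold higher number from compound 3 to compound 4 (0.48 log units; beyond the scatter), a modest move toward weaker inhibition. The read-out therefore responds at this position even though both groups carry one six-membered aromatic ring of carbon only and no hydrogen-bond donors or acceptors. Nothing at hand bears on the reason for this step. The exchange alters the substituent and its ring position together, so these compounds cannot separate the two. On these data alone, how an aminophenyl or a carboxylic acid on that ring would read remains open.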